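This account rests on a few compounds, and the source may have more. Where it says the series, first, only, none or still open, it means among the compounds named here.

Measured compounds in an ADME assay on MIA PaCa-2 cells (Homo sapiens) for cytotoxicity, read by MTT assay, with a stated time of 72 h; a lower number here means a stronger inhibitor, a higher number a weaker inhibitor:
compound 1, `C=CCOc1cc(C2=C(c3cc(OC)c(OC)c(OC)c3)C(=O)C(O)C2)ccc1OC`: > 100 ug/mL
compound 2, `COc1ccc(C2=C(c3cc(OC)c(OC)c(OC)c3)C(=O)C(OC(C)=O)C2)cc1`: < 1 ug/mL
compound 3, `COc1ccc(C2=C(c3cc(OC)c(OC)c(OC)c3)C(=O)C(OC(C)=O)C2)cc1OC(C)C`: > 100 ug/mL

The value of compound 1 is a limit of this assay. The value of compound 2 is also a limit, the one given as the limit of < 1 ug/mL in this assay, at which 1 of the 3 values shown sits. The value of compound 3 is a limit as well, sharing the limit of > 100 ug/mL in this assay, at which 2 of the 3 values shown sit, with compound 1. Two of the three values in this assay therefore sit at the upper limit, and compound 3 stands there. Within the data shown here, the only step between measured compounds that differ in one place is an at least 100-fold higher number from compound 2 to compound 3 (2.00 log units; beyond the scatter), a large loss on going to the isopropoxy compound.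

Compound 4, `COc1ccc(C2=C(c3cc(OC)c(OC)c(OC)c3)C(=O)C(O)C2)cc1OC(C)C`, differs from compound 3 by hydrogen in place of acetyl on an oxygen on a saturated carbon. Among the measured compounds shown here, no measured step covers this change. Compound 1 carries the hydroxy rather than the acetoxy group, and in this assay compound 1 gives only a limit. Compound 3 carries the isopropoxy group, and the step of an at least 100-fold higher number from compound 2 to compound 3 (2.00 log units; beyond the scatter) lands at the upper limit. Both neighbours of compound 4 thus sit at the limit, and compound 4 is expected to do the same, with no step beyond the scatter: a number no higher from compound 3 to compound 4 (the limit leaves the size open). Compound 4 is therefore estimated at 100 ug/mL, with a range of 50 ug/mL to 300 ug/mL.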

Compound 4, half-maximal inhibitory concentration: > 100 ug/mL
Compound 4: no number, only a limit; the forecaster's own chance of this, stated with the estimate: 80%; the middle value sits exactly at the limit.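

Compound 4, like compound 1 and compound 3, gives only a limit in this assay, so the steps from compound 3 to compound 4 and from compound 1 to compound 4 cannot be read: the limit of > 100 ug/mL in this assay, at which 3 of the 4 values shown sit.

The compounds shown leave open what acetoxy to hydroxy, or isopropyl in place of allyl, does to the number, as neither change has a number on both sides.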